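One small change from compound 2 to compound 4

This account rests on a few compounds, and the source may have more. Where it says the series, first, only, none or still open, it means among the compounds named here.

Values so far in a physicochemical assay for solubility, measured as thermodynamic solubility, at pH 7.4 (a higher number here means a more soluble compound, a lower number a less soluble compound), are these

- compound 1 `COc1nnc2ccc(N3CCC(c4ccc(N5CCC(N6CCN(C)C(=O)[C@H]6C)CC5)cc4)CC3)nn12` gives 760000 nM
- compound 2 `COc1nnc2ccc(N3CCC(c4ccc(OCCCCN5CCN(C)C(=O)[C@H]5C)cc4)CC3)nn12` gives 470000 nM
- compound 3 `CN1CCN(CCOc2ccc(C3CCN(c4ccc5nnc(C(F)(F)F)n5n4)CC3)cc2)C(=O)C1` gives 52000 nM

Repeat measurements of a single compound scatter somewhat, so close values cannot be ranked against each other. Compound 2 stands within that scatter of compound 1, so the two count as level. Compound 3 lies lower than both, well beyond the scatter.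

The next compound to be measured is compound 4 `COc1nnc2ccc(N3CCC(c4ccc(OCCCN5CCN(C)C(=O)[C@H]5C)cc4)CC3)nn12` and it differs from compound 2 in one place only. The change is a group of 9 heavy atoms (6 carbon, 2 nitrogen, 1 oxygen; one six-membered non-aromatic ring with 2 hetero atoms) in place of a group of 10 heavy atoms (7 carbon, 2 nitrogen, 1 oxygen; one six-membered non-aromatic ring with 2 hetero atoms), on a saturated chain carbon, three bonds along the chain from an oxygen on an aromatic ring and the rest of the molecule stays the same.

Within the data shown here, no two measured compounds differ in just one place, so the data show no direct example of what such a change does. Compound 3 at 52000 nM sits apart from the others, but it differs from compound 2 in several places at once and offers little guidance here. With so modest a change, no shift beyond the scatter is expected. The expected size is a 1.2-fold lower number from compound 2 to compound 4 (0.07 log units; within the scatter) and so stays within the scatter. For compound 4 the estimated value is 400000 nM (expected range 150000 nM to 800000 nM).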

Compound 4, solubility: > 1000000 nM
Compound 4: a limit, no number; the forecaster's own chance of this, stated with the estimate: 3%; at least 2.5-fold (0.39 log units) between middle value and limit.
By their numbers in this assay, from the lowest: compound 3; then compounds 2 and 1 (each within the scatter of the next). At a limit, above all of these: compound 4.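

Among these compounds, until now no two measured compounds differed in one place only, so nothing showed what this position could do alone. In this assay, putting a group of 9 heavy atoms in place of a group of 10 heavy atoms, on a saturated chain carbon, three bonds along the chain from an oxygen on an aromatic ring, gives an at least 2.1-fold higher number from compound 2 to compound 4 (0.32 log units; beyond the scatter), so a change this modest, with the rest of the molecule the same, can move the number beyond the scatter. Compound 4 reads > 1000000 nM, which is a limit of the assay and not a number, so the step gives only a minimum size and its true size stays unknown: the limit of > 1000000 nM in this assay, at which 1 of the 4 values shown sits.

On these data alone, one pair sets no rule, so it remains open whether a longer chain, a shorter chain, or an amine or a carboxylic acid at this place would shift the number in the same way. As far as these compounds go, it is also open how far compound 4 really lies from compound 2, and whether the same change would give a similar step on a different core.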